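The source may hold more compounds than are shown below. What is called first, only, known or untested is meant among the compounds shown, and "the series" means these compounds.

Compound 1 `O=C(Nc1cccc(-n2cc(-c3ccncc3)c(-c3cc(O)cc(Cl)c3)n2)c1)Nc1ccc(Cl)c(Cl)c1` gives 12.8% in a functional assay on NCI/ADR-RES cells (Homo sapiens) for inhibition, read by sulforhodamine B assay, with a stated time of 48 h, tested at 10 uM; on this read-out lower numbers stand for a stronger effect and higher numbers for a weaker effect at the one concentration tested. Compound 2 `COc1cc(Cl)cc(-c2nn(-c3cccc(NC(=O)Nc4ccc(Cl)c(Cl)c4)c3)cc2-c2ccncc2)c1` gives 8.59% in this assay. Compound 3 `O=C(Nc1cccc(-n2cc(-c3ccncc3)c(-c3cc(O)cc(Cl)c3)n2)c1)c1cc(C(F)(F)F)cc(C(F)(F)F)c1` gives 46.9% in this assay.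

Compound 2 differs from compound 1 by one change, (methyl in place of hydrogen on an oxygen on an aromatic ring), and that change made a step of a number 4.2 percentage points lower from compound 1 to compound 2 (within the scatter). The difference between the core of compound 1 and the core of compound 3 is not broken down here; their two values show compound 3 standing well higher. Compound 4 `COc1cc(Cl)cc(-c2nn(-c3cccc(NC(=O)c4cc(C(F)(F)F)cc(C(F)(F)F)c4)c3)cc2-c2ccncc2)c1`, not yet measured, differs from compound 3 by the same change, (methyl in place of hydrogen on an oxygen on an aromatic ring). Since that change made only a small step in this assay from compound 1 to compound 2, the step is expected to be a number 3.9 percentage points lower from compound 3 to compound 4 (within the scatter) from compound 3 to compound 4. Compound 4 is therefore estimated at 43%, between 28% and 60%.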

Compound 4, a percentage reported as activity, at one concentration (the size of the read-out at that concentration, not a potency): 67.8%
Compound 4: middle estimate off by 24.8 percentage points, on the low side; the measured number lies above the stated range.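

Swapping hydroxy for methoxy gave a number 20.9 percentage points higher from compound 3 to compound 4 (beyond the scatter) in this assay, so on this core the change goes with a weaker effect at the one concentration tested. The same change therefore does not carry over with the same result from one core to the other: the same change on two cores in this assay, a number 4.2 percentage points lower (within the scatter) from compound 1 to compound 2 and a number 20.9 percentage points higher (beyond the scatter) from compound 3 to compound 4, 25.1 percentage points apart, beyond the scatter of two such steps

Going by these compounds alone, with only two pairs of compounds, this shows that the step depends on the core, but not why the two steps differ or what the change would do on any further core. The compounds shown leave open what other groups would do in place of the hydroxy, such as a longer chain like ethoxy or an amine.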